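The source may report more compounds than this note shows. Statements on the series, on what has been measured and on what is new or still open speak of the compounds shown alone.

- Compound 1 `NC(=O)c1cc(Br)ccc1NC(=O)/C=C/c1ccccc1Br`: 46.2%
- Compound 2 `NC(=O)c1cc(Br)ccc1NC(=O)/C=C/c1cccc(Br)c1`: 45.9%

In a functional assay on K562 cells (Homo sapiens) for antiproliferative activity, read by trypan blue exclusion, with a stated time of 48 h, tested at 10 uM (on this read-out higher numbers stand for more inhibition of growth at the one concentration tested and lower numbers for less inhibition of growth), compound 2 gives 45.9%. Going by the values given here, that is one of only two numbers so far, and it lies within the scatter of compound 1 at 46.2%. Compound 3 `Cc1ccccc1/C=C/C(=O)Nc1ccc(Br)cc1C(N)=O` differs from compound 2 by one swap, 2-methylphenyl in place of 3-bromophenyl on a double-bonded chain carbon bound to a double-bonded chain carbon. Among the compounds with values here, one measured step bears on this place, a number 0.3 percentage points lower from compound 1 to compound 2 (within the scatter), and it was too small to separate from the scatter. Within the data shown here, no measured compound carries a methyl group here, so the entering group is untested, and the range must stay wide. The expected step is a number 0.9 percentage points lower from compound 2 to compound 3 (within the scatter), with no change beyond the scatter anticipated. For compound 3 the estimated value is 45%, with an expected range of 30% to 60%.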

Compound 3, percent growth inhibition at one concentration: 43.2%
Compound 3: the middle estimate sits 1.8 percentage points above what was measured; the measured number falls inside the stated range.
By their numbers in this assay, from the lowest: compounds 3, 2 and 1 (each within the scatter of the next).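

In this assay, the swap of 3-bromophenyl for 2-methylphenyl on a double-bonded chain carbon bound to a double-bonded chain carbon gives a number 2.7 percentage points lower from compound 2 to compound 3 (within the scatter). The closer comparison exchanges only methyl for bromo on an aromatic carbon and gives a number 3 percentage points lower from compound 1 to compound 3 (within the scatter), so among these three compounds, bromine on this ring is not required for this level of growth inhibition.

From the compounds shown here alone, all three groups here are phenyl rings carrying bromo or methyl, so it remains open whether an amine, a carboxylic acid or a methoxy group on this ring would give a number beyond the scatter. Results at one concentration also leave open how the compounds would compare at other concentrations. Nothing measured here explains why bromo and methyl read alike.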